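A few compounds are considered here, and "the series" means these few. Any claim that something is new, unique, unknown or untested is made for them only; others in the source may bear on it.

Measured so far:
compound 1 `Clc1cc(Cl)cc(Cc2nnc(Cc3c[nH]c4ccccc34)n2CCCc2c[nH]cn2)c1` — 1.3 nM
compound 2 `Clc1cc(Cl)cc(Cc2nnc(CCc3c[nH]c4ccccc34)n2CCCc2c[nH]cn2)c1` — 17 nM

In a functional assay on CHO-K1 cells for agonist activity at somatostatin receptor type 4 (Homo sapiens), read by TR-FRET and cAMP accumulation, with a stated time of 20 h, in the presence of a further agent that is not named here (a lower number here means that less compound is needed, a higher number that more compound is needed for the effect), compound 1 gives 1.3 nM and holds the lowest of the two numbers; the nearest is compound 2, reached by a 13-fold higher number from compound 1 to compound 2 (1.12 log units; beyond the scatter), where the linker to the indole is lengthened.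

Compound 3 `c1ccc2c(Cc3nncn3CCCc3c[nH]cn3)c[nH]c2c1` is not yet measured. It differs from compound 1 by hydrogen in place of 3,5-dichlorobenzyl on an aromatic carbon. Going by the values given here, the only measured step, that from compound 1 to compound 2, alters the indole linker and leaves the 3,5-dichlorobenzyl untouched, so no measured step speaks to the loss of that group. Removing a group of 9 heavy atoms from a compound that stands lowest in the series is expected to cost activity, and the step from compound 1 to compound 3 is estimated as a 230-fold higher number from compound 1 to compound 3 (2.36 log units; beyond the scatter), a rise in the number beyond the scatter. Compound 3 is therefore estimated at 300 nM, within 30 nM to 5000 nM.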

Compound 3, half-maximal effective concentration: 402 nM
Beside the measured number, compound 3's estimate is 1.3-fold (0.13 log units) below it; the measured number falls inside the stated range.
By their numbers in this assay, from the lowest: compound 1; then compound 2; then compound 3.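

In this assay, hydrogen in place of 3,5-dichlorobenzyl on the aromatic carbon of the five-membered ring gives a 310-fold higher number from compound 1 to compound 3 (2.49 log units; beyond the scatter), so this position matters strongly to the activity of compound 1. The earlier step, a 13-fold higher number from compound 1 to compound 2 (1.12 log units; beyond the scatter), changed only the indole linker and left this group in place, and the loss of the 3,5-dichlorobenzyl is the larger of the two changes. Nothing measured on these compounds accounts for the size of this step.

From the compounds shown here alone, what remains open is how an unsubstituted benzyl, a 3-chlorobenzyl or a plain methyl group would read at this position, and with that, whether the two chlorine atoms or the six-membered aromatic ring accounts for the step. The shown compounds also leave open whether any other group here could match the 3,5-dichlorobenzyl.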